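The compounds below may be only part of what the source reports. "The series", "measured", "known", "first", "only" and "open" are said of these compounds alone.

Of the compounds shown here, three that share one core have been tested in a functional assay on Lu1 cells (Homo sapiens) for cytotoxicity, read by sulforhodamine B assay; a lower number here means that less compound is needed, a higher number that more compound is needed for the effect. Compound 1 `C=C1CC[C@@H]2[C@](C)(CO[Si](c3ccccc3)(c3ccccc3)C(C)(C)C)[C@H](OC(C)=O)CC[C@@]2(C)[C@@H]1C/C=C1/C(=O)OC[C@H]1O` gives 10.9 uM in this assay. Compound 3 `C=C1CC[C@@H]2[C@](C)(COC(C)=O)[C@H](O)CC[C@@]2(C)[C@@H]1C/C=C1/C(=O)OC[C@H]1O` gives 14 uM. Compound 2 `C=C1CC[C@@H]2[C@](C)(CO)[C@H](OC(C)=O)CC[C@@]2(C)[C@@H]1C/C=C1/C(=O)OC[C@H]1O` gives 30.6 uM, the highest of the three numbers: compound 3 lies nearest, its lower number still beyond the scatter, and compound 1 lies furthest, also beyond the scatter. No pair among these three differs in a single place, so each pair shows only what its two values show.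

Compound 4 `C=C1CC[C@@H]2[C@](C)(CO[Si](C)(C)C(C)(C)C)[C@H](OC(C)=O)CC[C@@]2(C)[C@@H]1C/C=C1/C(=O)OC[C@H]1O` has not yet been measured in this assay. It differs from compound 2 by a group of 7 heavy atoms (6 carbon, 1 silicon; no ring) in place of a hydrogen atom, on an oxygen on a saturated carbon. Compound 1, which likewise bears a silicon-containing group rather than the free hydrogen, gives 10.9 uM, and this is the closest guide available. In this assay a moderate fall in the number is expected, a 2.0-fold lower number from compound 2 to compound 4 (0.31 log units; beyond the scatter). Compound 4 is therefore estimated at 15 uM, with a likely range from 6 uM to 35 uM.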

Compound 4, concentration for half-maximal effect: 9.62 uM
The estimate for compound 4 lay 1.6-fold (0.19 log units) above the measured number, within the range that was stated.
By their numbers in this assay, from the lowest: compounds 4, 1 and 3 (each within the scatter of the next); then compound 2.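

For the compounds shown here, compound 2 and compound 4 are the first pair here that differ in one place, so the effect of replacing the hydrogen on this oxygen can now be read directly: in this assay the change gives a 3.2-fold lower number from compound 2 to compound 4 (0.50 log units; beyond the scatter), a modest step beyond the scatter. With a second silicon-containing group in hand, compound 1 at 10.9 uM and compound 4 at 9.62 uM sit within the scatter of each other, so the exact group of this kind makes no readable difference between these two. Nothing available explains why the number falls.

On these data alone, whether a benzyl group or a longer carbon chain on this oxygen would move the number in the same way stays open. So does the question of whether the silicon itself plays any part.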